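The source may report more compounds than this note shows. Statements on the series, on what has been measured and on what is new or still open speak of the compounds shown alone.

Working notes on the series. The shared core is that of compound 1 `CN1CCCN(CCn2ccc3ccc(N)cc32)CC1`, with the substituent on the aromatic carbon varied. In an assay on HEK293 cells for binding affinity to 5-hydroxytryptamine receptor 7 (Homo sapiens), read by radioligand binding, tested at 1 uM (a higher number here means more inhibition at the concentration tested (going by the name of the read-out), a lower number less inhibition), compound 1 gives 0%. Compound 2 `CN1CCCN(CCn2ccc3ccc(C(F)(F)F)cc32)CC1` gives 89% in this assay, and compound 3 `CC(C)c1ccc2ccn(CCN3CCCN(C)CC3)c2c1` gives 72%. On these three numbers compound 3 stands second highest; the nearest other number is separated by the step of a number 17 percentage points lower from compound 2 to compound 3 (beyond the scatter), and the widest gap in the set is the step of a number 72 percentage points higher from compound 1 to compound 3 (beyond the scatter).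

Compound 4 `CN1CCCN(CCn2ccc3ccc(-c4cccnc4)cc32)CC1` carries the change (pyridin-3-yl in place of isopropyl on an aromatic carbon). Among the compounds with values here, no measured step introduces a pyridin-3-yl, so nothing bears on the change directly. The steps at this position show that leaving amino behind gives large gains, a number 89 percentage points higher from compound 1 to compound 2 (beyond the scatter) and a number 72 percentage points higher from compound 1 to compound 3 (beyond the scatter), while exchanging one non-amino group for another gives only the modest step of a number 17 percentage points lower from compound 2 to compound 3 (beyond the scatter). The change from isopropyl to pyridin-3-yl is another exchange between non-amino groups, so the expected step in this assay is a number 12 percentage points lower from compound 3 to compound 4 (beyond the scatter), small and with wide uncertainty in either direction. Compound 4 is therefore estimated at 60% in this assay, within a range of 20% to 90%.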

Compound 4, a percentage reported as inhibition, at one concentration (the size of the read-out at that concentration, not a potency): 35%
Estimate against measurement, compound 4: 25 percentage points above; the range from low to high includes it.
By their numbers in this assay, from the lowest: compound 1; then compound 4; then compound 3; then compound 2.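

In this assay, within the data shown here, an exchange between non-amino groups at this position can be large: pyridin-3-yl in place of isopropyl gives a number 37 percentage points lower from compound 3 to compound 4 (beyond the scatter) and pyridin-3-yl in place of trifluoromethyl gives a number 54 percentage points lower from compound 2 to compound 4 (beyond the scatter) in this series, whereas the one such exchange among the earlier compounds was modest. Leaving amino behind still brings a large gain with this third group, at a number 35 percentage points higher from compound 1 to compound 4 (beyond the scatter) for pyridin-3-yl in place of amino, so all three non-amino groups stand higher than amino, but the size of the gain now clearly depends on the group that enters. No data shown here bear on why the one group with a ring and a hetero atom stands below both isopropyl and trifluoromethyl.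

As far as these compounds go, whether the lower number goes with the aromatic ring itself or with its nitrogen stays open, and a plain phenyl group at this position would separate the two. Also open, from the compounds shown here alone, is how the isomeric pyridin-2-yl and pyridin-4-yl groups, or a small group such as methyl or chlorine, would stand against these values.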